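Hydrazone series: aryl variation and tolerance by macrophages

A few compounds are considered here, and "the series" means these few. Any claim that something is new, unique, unknown or untested is made for them only; others in the source may bear on it.

Three hydrazones of a shared core have been read in an ADME assay on J774 cells (Mus musculus, strain BALB/c) for cytotoxicity, read by resazurin assay, with a stated time of 72 h; a lower number here means that less compound is tolerated, a higher number that more compound is tolerated. Compound 1 `CC(/C=N/Nc1ccc([N+](=O)[O-])cc1)=N\NC(=O)c1ccc(O)cc1` gives 51000 nM in this assay. Compound 2 `CC(/C=N/Nc1ccc([N+](=O)[O-])cc1)=N\NC(=O)c1ccccc1C` reaches only a limit of the assay, > 100000 nM, and no number (the limit of > 100000 nM in this assay, at which 1 of the 3 values shown sits). Compound 3 `CC(/C=N/Nc1ccc([N+](=O)[O-])cc1)=N\NC(=O)c1ccccc1N` gives 29800 nM, the lowest number shown; the step of a 1.7-fold lower number from compound 1 to compound 3 (0.23 log units; within the scatter) lies within the scatter, whereas an at least 3.3-fold lower number from compound 2 to compound 3 (0.52 log units; beyond the scatter) is beyond it, and an at least 1.9-fold higher number from compound 1 to compound 2 (0.29 log units; that floor lies within the scatter) has a floor inside the scatter.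

Compound 4 `COc1cc(C(=O)N/N=C(C)/C=N/Nc2ccc([N+](=O)[O-])cc2)ccc1O` differs from compound 3 by 4-hydroxy-3-methoxyphenyl in place of 2-aminophenyl on a carbonyl carbon. Going by the values given here, the three measured steps all vary the aryl on the carbonyl carbon, and only the one away from the methyl analogue clears the scatter. A hydroxy-bearing aryl, as in compound 1 at 51000 nM, gave a number within the scatter of compound 3. For compound 4 a step near the scatter edge, a 1.5-fold higher number from compound 3 to compound 4 (0.18 log units; within the scatter), is therefore expected in this assay, upward if anything. The estimate for compound 4 is 45000 nM, with a range from 20000 nM to 100000 nM.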

Compound 4, half-maximal cytotoxic concentration: > 100000 nM
Compound 4: a limit, no number; the forecaster's own chance of this, stated with the estimate: 20%; at least 2.2-fold (0.34 log units) between middle value and limit.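

In this assay, 4-hydroxy-3-methoxyphenyl in place of 2-aminophenyl on the carbonyl carbon gives an at least 3.3-fold higher number from compound 3 to compound 4 (0.52 log units; beyond the scatter), so this position now has a second step beyond the scatter leading away from the 2-aminophenyl analogue. Methoxy in place of hydrogen on an aromatic carbon gives an at least 1.9-fold higher number from compound 1 to compound 4 (0.29 log units; that floor lies within the scatter), and with that floor inside the scatter the series does not show that this added methoxy changes tolerance. Compound 4 reaches a limit and no number: the limit of > 100000 nM in this assay, at which 2 of the 4 values shown sit.

As far as these compounds go, compound 2 and compound 4 both stand at limits, the step between them cannot be read, and the order of these two aryl groups stays open. Also open, from the compounds shown here alone, is whether an aryl carrying a carboxylic acid or a dimethylamino group on the carbonyl carbon would fall near compound 3 or reach the limit.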